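Fluoro for hydrogen on the phenyl of compound 2

The compounds below may be only part of what the source reports. "The series", "measured", "known", "first", "only" and "open" are said of these compounds alone.

Compound 1 `O=C(Nc1ccc(Oc2ccnc3[nH]ccc23)cc1)c1cc2cccnc2n(-c2ccc(F)cc2)c1=O`: 1360 nM
Compound 2 `Cn1ccc2c(Oc3ccc(NC(=O)c4cc5cccnc5n(-c5ccccc5)c4=O)cc3)ccnc21`: 5030 nM

Both compounds were tested in a functional assay on U-87MG ATCC cells for antiproliferative activity against U-87 MG (Homo sapiens), read by MTT assay, with a stated time of 72 h; a higher number here means a weaker inhibitor, a lower number a stronger inhibitor. Going by the values given here, compound 2 has the highest number of the two; compound 1 sits a clear distance lower, and the two differ in more than one place, so no single step links them. Compound 3 `Cn1ccc2c(Oc3ccc(NC(=O)c4cc5cccnc5n(-c5ccc(F)cc5)c4=O)cc3)ccnc21` differs from compound 2 in one place only: fluoro in place of hydrogen on an aromatic carbon. No measured step of this kind exists among these compounds, so the expected change is small and uncertain. The step of a 1.4-fold lower number from compound 2 to compound 3 (0.16 log units; within the scatter) is estimated as modest, toward a lower number. Compound 3 is expected to give about 3500 nM in this assay, within 1200 nM to 9000 nM.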

Compound 3, half-maximal inhibitory concentration: 2120 nM
The estimate for compound 3 lay 1.7-fold (0.22 log units) above the measured number; low and high end bracket the measured number.
By their numbers in this assay, from the lowest: compounds 1 and 3 (each within the scatter of the next); then compound 2.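

In this assay, fluoro in place of hydrogen para to a large group gives a 2.4-fold lower number from compound 2 to compound 3 (0.38 log units; beyond the scatter), so this position of the phenyl ring responds to even a single-atom change. Methyl in place of hydrogen on the aromatic nitrogen, seen in a 1.6-fold higher number from compound 1 to compound 3 (0.19 log units; within the scatter), stays within the scatter, so the two fluoro compounds cannot be told apart in this assay. Nothing available explains the effect of the fluoro. From the compounds shown here alone, whether chloro, methoxy or an amine on the same carbon would shift the number further remains open.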